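The source may hold more compounds than are shown below. What is called first, only, known or untested is meant among the compounds shown, and "the series" means these compounds.

Measured compounds in an ADME assay for permeability, using PAMPA; on this read-out higher numbers stand for higher permeability and lower numbers for lower permeability:
- compound 1 `CCCC[C@H](NC(=O)[C@H](CCCCN)NC(=O)[C@H](CCCNC(=N)N)NC(=O)c1ccc(/C=C2\SC(=O)N(C3CCCCC3)C2=O)cc1)C(N)=O`: 1.69 10^-6 cm/s
- compound 2 `CCCC[C@H](NC(=O)[C@H](CCCCN)NC(=O)[C@H](CCCNC(=N)N)NC(=O)c1ccc(/C=C2\SC(=O)N(c3ccc(C)cc3)C2=O)cc1)C(N)=O`: 0.66 10^-6 cm/s
- compound 3 `CCCC[C@H](NC(=O)[C@H](CCCCN)NC(=O)[C@H](CCCNC(=N)N)NC(=O)c1ccc(/C=C2\SC(=S)N(C3CCCC3)C2=O)cc1)C(N)=O`: 2.31 10^-6 cm/s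

Compound 2 gives the lowest of the three numbers in this assay; compound 1 lies above it by a 2.6-fold lower number from compound 1 to compound 2 (0.41 log units; beyond the scatter) read in reverse, and compound 3 lies higher still. Compound 3 differs from compound 1 in two places, so only the two values themselves can be compared there.

Compound 4 `CCCC[C@H](NC(=O)[C@H](CCCCN)NC(=O)[C@H](CCCNC(=N)N)NC(=O)c1ccc(/C=C2\SC(=O)N(CCOC(C)=O)C2=O)cc1)C(N)=O` is not yet measured. It differs from compound 2 in one place: 2-acetoxyethyl in place of 4-methylphenyl on an amide-type nitrogen in a ring. Among the measured compounds shown here, only one measured step touches the group on this ring nitrogen: a 2.6-fold lower number from compound 1 to compound 2 (0.41 log units; beyond the scatter), where a ring without aromaticity was exchanged for 4-methylphenyl and the number fell. For the measured compounds named here, compound 4 carries no ring at this position but a chain with two hydrogen-bond acceptors; no measured pair shows such an exchange. The step from compound 2 to compound 4 is therefore expected to be small, a 1.5-fold higher number from compound 2 to compound 4 (0.18 log units; within the scatter), with either direction possible. For compound 4 the estimate in this assay is 1 10^-6 cm/s, ranging from 0.4 10^-6 cm/s to 2.5 10^-6 cm/s.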

Compound 4, apparent permeability: "impermeable" (no number reported)
The entry for compound 4 holds no number; no gap can be computed for the estimate.
By their numbers in this assay, from the lowest: compound 2; then compounds 1 and 3 (each within the scatter of the next).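

In this assay, among the compounds shown here, compound 4 is reported as "impermeable" with no number, so no step from compound 2 to compound 4 can be read. The compounds shown leave open what size of gap separates compound 4 from compound 2. No measurement shown bears on this result.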